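One Stereocentre Inverted: How Much Does Tolerance Shift?

This account rests on a few compounds, and the source may have more. Where it says the series, first, only, none or still open, it means among the compounds named here.

Three related compounds set the scene in an ADME assay on Vero cells (Chlorocebus sabaeus) for cytotoxicity, read by resazurin assay, with a stated time of 72 h; a higher number here means that more compound is tolerated, a lower number that less compound is tolerated. Compound 3 `CCCCC1(CCCC)C[C@@H](CNCCCn2ccnc2)[C@](C)(OC)OO1` gives 140000 nM, the higher of the two numbers available. Compound 1 `CCCCC1(CCCC)C[C@@H](CNCCCn2ccnc2)[C@@](CCCC)(OC)OO1` gives 32500 nM, a lower number, and the gap between the two lies beyond the usual scatter. For compound 2 `CCCCC1(CCCC)C[C@@H](CNCCCn2cncn2)[C@@](C)(OC)OO1` the entry reads "not determined" (no result reported), so it adds nothing to the comparison.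

The next compound to be tested, compound 4 `CCCCC1(CCCC)C[C@@H](CNCCCn2ccnc2)[C@@](C)(OC)OO1`, departs from compound 3 in one respect only: the two compounds have the same atoms and bonds and differ only in configuration as drawn: 1 of 2 stereo elements differ; a stereocentre at a saturated ring carbon is drawn R in compound 3 and S in compound 4. No group leaves or enters, and a stereocentre at a saturated ring carbon is drawn R in compound 3 and S in compound 4. For the measured compounds named here, no measured pair in this small set isolates a change of configuration alone, so the data give no direct guide to its size. Compound 1 differs from compound 3 in more than one place, so its lower number cannot be read as the outcome of this inversion. With compound 3 at 140000 nM as the closest anchor, a modest move towards a lower number is expected, most likely none beyond the scatter. The estimated change is a 1.4-fold lower number from compound 3 to compound 4 (0.15 log units; within the scatter). For compound 4 the estimated value is 100000 nM, with an expected range of 40000 nM to 250000 nM.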

Compound 4, half-maximal cytotoxic concentration: 74500 nM
The estimate for compound 4 lay 1.3-fold (0.13 log units) above the measured number; the measured number falls inside the stated range.
By their numbers in this assay, from the lowest: compound 1; then compounds 4 and 3 (each within the scatter of the next).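

In this assay, for the compounds shown here, the inversion of the stereocentre at a saturated ring carbon can now be read directly for the first time, as a 1.9-fold lower number from compound 3 to compound 4 (0.27 log units; within the scatter), so at this position the change of configuration as drawn stays inside the scatter. Going by these compounds alone, the new result also gives the first single-change reading at the chain on that core, with hydrogen in place of propyl on a saturated chain carbon bound to a saturated ring carbon: a 2.3-fold higher number from compound 1 to compound 4 (0.36 log units; beyond the scatter), a modest step, but the only one of the two that lies beyond the scatter. The first of these readings is a clean test of configuration alone, with no group leaving or entering, and it rests on one fact: the fact that compounds 3 and 4 differ only in the configuration as drawn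

The compounds shown leave open whether the same inversion would stay inside the scatter in a compound carrying the longer chain of compound 1, or in one carrying the other azole ring of compound 2. They also leave open how a hydroxyl group, an amine or a phenyl ring on that saturated chain carbon would compare with hydrogen and propyl.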